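The source may report more compounds than this note shows. Statements on the series, on what has been measured and on what is new or still open speak of the compounds shown alone.

Compound 1 `O=C1N(Cc2ccccc2)CCCN1Cc1ccccc1` has no result reported in an assay on isolated protein for inhibition of Myeloperoxidase (Homo sapiens), with a stated time of 5 min, in the presence of a further agent that is not named here; on this read-out higher numbers stand for weaker inhibition and lower numbers for stronger inhibition. For the measured compounds named here, compound 2 `Oc1ccccc1CNCCCc1ccccc1` is therefore the only compound with a number in this assay, where compound 2 gives 1200 nM; with a single value there is nothing to rank it against. Compound 3 `Oc1ccccc1CCCNCc1ccccc1O` differs from compound 2 by hydroxy in place of hydrogen on an aromatic carbon. Going by the values given here, no measured pair shows the effect of such a change, so the step from compound 2 to compound 3 is expected to stay within the usual scatter, as a 1.3-fold lower number from compound 2 to compound 3 (0.12 log units; within the scatter). Compound 3 is estimated at 900 nM, between 300 nM and 3000 nM in this assay.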

Compound 3, half-maximal inhibitory concentration: 350 nM
Compound 3: middle estimate off by 2.6-fold (0.41 log units), on the high side; the measured number falls inside the stated range.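

In this assay, hydroxy in place of hydrogen on an aromatic carbon, ortho to a large group, gives a 3.4-fold lower number from compound 2 to compound 3 (0.54 log units; beyond the scatter) and so goes with modestly stronger inhibition. For the compounds shown here, this is the first measured sign that this place on the ring responds to a change. Nothing available here explains the gain. From the compounds shown here alone, whether a methoxy group or a fluorine atom in the same place would give a similar step remains open. So does whether a longer chain between the two rings would keep it.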